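This account rests on a few compounds, and the source may have more. Where it says the series, first, only, none or still open, it means among the compounds named here.

Measured in a functional assay on K562 cells (Homo sapiens) for cytotoxicity, read by MTT assay, with a stated time of 3 days; a higher number here means a weaker inhibitor, a lower number a stronger inhibitor:

- compound 1 `CCNc1nc(SCc2nc3ccccc3[nH]2)nc(-c2ccccc2)c1C#N` gives 4.38 nM
- compound 2 `N#Cc1c(Nc2nccs2)nc(SCc2nc3ccccc3[nH]2)nc1-c1ccccc1` gives 14.7 nM
- compound 3 `N#Cc1c(NC(N)=S)nc(SCc2nc3ccccc3[nH]2)nc1-c1ccccc1` gives 11.9 nM

Of these three numbers, compound 3 belongs to the higher pair. It is separated from its partner only by a 1.2-fold lower number from compound 2 to compound 3 (0.09 log units; within the scatter). Compound 1 holds the lowest number, with a 2.7-fold higher number from compound 1 to compound 3 (0.43 log units; beyond the scatter) and a 3.4-fold higher number from compound 1 to compound 2 (0.53 log units; beyond the scatter) on the way to the other two.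

Compound 4 `N#Cc1c(NC(N)=O)nc(SCc2nc3ccccc3[nH]2)nc1-c1ccccc1` keeps the shared core and has not yet been measured in this assay. The change is confined to one substituent: a group of 3 heavy atoms (1 carbon, 1 nitrogen, 1 oxygen; no ring) in place of a group of 3 heavy atoms (1 carbon, 1 nitrogen, 1 sulfur; no ring), on a nitrogen on an aromatic ring. Carbamoyl enters on a nitrogen on an aromatic ring, and the group that leaves holds sulfur where carbamoyl holds oxygen.

Within the data shown here, no measured pair isolates this exchange. The nearest evidence comes from other changes at the same nitrogen. These gave modest steps when ethyl was replaced, but the step to compound 3 from the 1,3-thiazol-2-yl compound, a 1.2-fold lower number from compound 2 to compound 3 (0.09 log units; within the scatter), stayed within the scatter. No step beyond the scatter is therefore expected, and no direction can be favoured. The expected step is a 1.1-fold higher number from compound 3 to compound 4 (0.04 log units; within the scatter), a small one. For compound 4 the estimated value is 13 nM, with an expected range from 5 nM to 32 nM as its limits.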

Compound 4, half-maximal inhibitory concentration: 4.54 nM
Compound 4: the middle estimate sits 2.9-fold (0.46 log units) above what was measured; measured number outside the range, below it.
By their numbers in this assay, from the lowest: compounds 1 and 4 (each within the scatter of the next); then compounds 3 and 2 (each within the scatter of the next).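

In this assay, the exchange of sulfur for oxygen at this place, on a nitrogen on an aromatic ring, is a real step (a 2.6-fold lower number from compound 3 to compound 4 (0.42 log units; beyond the scatter)), even though the two groups match in heavy-atom count, rings and hydrogen-bond donors and acceptors. Among these compounds, this breaks the picture left by the earlier compounds, in which both replacements of ethyl gave higher numbers: carbamoyl also stands apart from 1,3-thiazol-2-yl (a 3.2-fold lower number from compound 2 to compound 4 (0.51 log units; beyond the scatter)) but cannot be told from ethyl (a 1.0-fold higher number from compound 1 to compound 4 (0.02 log units; within the scatter)), so a group on this nitrogen need not cost activity when ethyl is replaced, and a single atom in it can decide the outcome. Nothing available here accounts for the difference between the oxygen and sulfur groups.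

The compounds shown do not say how other groups on this nitrogen would behave, such as acetyl, which holds a carbonyl but no second nitrogen, a longer chain such as butyl, or a chain ending in an amine. On these data alone, they also speak only for this assay, so it remains open whether the gap between carbamoyl and its sulfur counterpart would appear on other cells.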